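Trimming the Methyl from the Ether of Compound 2

The source may hold more compounds than are shown below. What is called first, only, known or untested is meant among the compounds shown, and "the series" means these compounds.

Compound 1, `CCCS(=O)(=O)c1cc(C#Cc2cc(Cl)ccc2OCC(=O)O)c(C)cc1NC(C)=O`: 1.3 nM in an assay on CHO cells for displacement of a labelled ligand from prostaglandin D2 receptor 2 (Homo sapiens), read by scintillation counting; a lower number here means a stronger inhibitor, a higher number a weaker inhibitor
Compound 2, `COCc1ccc(F)c(C#Cc2cc(Cl)ccc2OCC(=O)O)c1`: 72 nM in this assay

Of the two compounds measured in this assay, compound 2 gives the higher number, and its gap to compound 1 lies beyond the scatter. Compound 3, `O=C(O)COc1ccc(Cl)cc1C#Cc1cc(CO)ccc1F`, has not yet been measured; it differs from compound 2 by hydrogen in place of methyl on an oxygen on a saturated carbon. Among the measured compounds shown here, no such step has been measured between any two compounds here. A change this small, at the far end of the methoxymethyl, is expected to move the number only a little, in either direction, likely within the scatter. Compound 3 is therefore expected to give 80 nM, between 25 nM and 250 nM, an expected step of a 1.1-fold higher number from compound 2 to compound 3 (0.05 log units; within the scatter).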

Compound 3, inhibition constant: 73 nM
The estimate for compound 3 lay 1.1-fold (0.04 log units) above the measured number; the measured number falls inside the stated range.
By their numbers in this assay, from the lowest: compound 1; then compounds 2 and 3 (each within the scatter of the next).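

In this assay, putting hydrogen in place of methyl on this oxygen, which turns methoxymethyl into hydroxymethyl, gives a step within the scatter (a 1.0-fold higher number from compound 2 to compound 3 (0.01 log units; within the scatter)). So at this position, compound 2 and compound 3 cannot be told apart by this read-out, and the end of the ether can be trimmed with no measurable cost here. Nothing available accounts for this result.

From the compounds shown here alone, whether an aminomethyl group or a longer chain such as ethoxymethyl would behave the same way remains open. So does the effect of removing the whole hydroxymethyl group.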